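From dichlorophenyl urea to acetylphenyl urea in BJ cells

The source may report more compounds than this note shows. Statements on the series, on what has been measured and on what is new or still open speak of the compounds shown alone.

Measured so far in an ADME assay on BJ cells (Homo sapiens) for antiproliferative activity, with a stated time of 72 h; a higher number here means that more compound is needed for the effect, a lower number that less compound is needed:
Compound 1 `COc1ccc(-c2cc(=O)c3c(OC)cc(OC)cc3n2S(=O)(=O)c2ccc([N+](=O)[O-])cc2)cc1` gives only a limit, > 29300 nM.
Compound 2 `COC(=O)c1cc(=O)c2cc(NC(=O)Nc3ccc(Cl)c(C(F)(F)F)c3)ccc2[nH]1` gives only a limit, > 12600 nM.
Compound 3 `COC(=O)c1cc(=O)c2cc(NC(=O)Nc3ccc(Cl)c(Cl)c3)ccc2[nH]1` gives only a limit, > 12600 nM.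

Compound 3 thus stands at a limit, as do the two other measured compounds, so no true number is known for any of the three. The step from compound 2 to compound 3, a step that the two limits leave unreadable from compound 2 to compound 3, cannot be read for that reason. Compound 4 `COC(=O)c1cc(=O)c2cc(NC(=O)Nc3cccc(C(C)=O)c3)ccc2[nH]1` differs from compound 3 by 3-acetylphenyl in place of 3,4-dichlorophenyl on an amide-type nitrogen. Among the measured compounds shown here, no measured step bears on this change, since the limit of > 12600 nM in this assay, at which 2 of the 3 values shown sit, and the limit of > 29300 nM in this assay, at which 1 of the 3 values shown sits, show only where the limits sit. Compound 4 is therefore expected to remain near the same limit, with an estimated step that the limit leaves unreadable from compound 3 to compound 4. The estimate for compound 4 in this assay is 20000 nM, ranging from 8000 nM to 60000 nM.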

Compound 4, half-maximal effective concentration: > 16000 nM
Compound 4 gave a limit, no number; the forecaster's own chance of this, stated with the estimate: 85%; the middle value is on the limit's open side.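

Compound 3 and compound 4 both give only a limit in this assay, not a number, so the step between them cannot be read. The compounds shown leave open what concentration any of them actually needs for the effect.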